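Chloro for Hydrogen on the Anilino Ring

The compounds below may be only part of what the source reports. "The series", "measured", "known", "first", "only" and "open" are said of these compounds alone.

Measured so far:
Compound 1 `S=C(N/N=C/c1ccc(Oc2ccccc2)cc1)Nc1ccc(Cl)cc1`: 5.64
Compound 2 `Cc1cc(Oc2ccc(/C=N/NC(=S)Nc3ccccc3)cc2)ccc1Cl`: 6.03

In a physicochemical assay for lipophilicity, in phosphate buffer, measured as octanol-water partition, with a stated time of 24 h (on this read-out higher numbers stand for higher lipophilicity and lower numbers for lower lipophilicity), compound 2 gives 6.03, the higher of the two numbers, and compound 1 gives 5.64, a gap beyond the usual scatter. Compound 3 `Cc1cc(Oc2ccc(/C=N/NC(=S)Nc3ccc(Cl)cc3)cc2)ccc1Cl` has not been measured. It differs from compound 2 in one place: chloro in place of hydrogen on an aromatic carbon. Within the data shown here, no pair of measured compounds shows this change, so the step can only be estimated. For compound 3 a rise in this assay is expected, roughly a number 0.57 log units higher from compound 2 to compound 3 (beyond the scatter). Compound 3 is thus estimated at 6.6, expected to fall between 6.2 and 7.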

Compound 3, partition coefficient: 6.59
Beside the measured number, compound 3's estimate is 0.01 log units above it; low and high end bracket the measured number.
By their numbers in this assay, from the lowest: compound 1; then compound 2; then compound 3.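

Chloro in place of hydrogen on an aromatic carbon, para to a large group, now has a measured size, a number 0.56 log units higher from compound 2 to compound 3 (beyond the scatter), in this assay. With (4-chlorophenyl)amino held constant, 4-chloro-3-methylphenyl in place of phenyl on an oxygen on an aromatic ring gives a number 0.95 log units higher from compound 1 to compound 3 (beyond the scatter), so both ends of compound 3 have been read as single changes. Nothing available explains the size of either step.

On these data alone, what an amine, a carboxylic acid or a methoxy group would do at this same place stays open. So does whether chloro would give a similar step elsewhere on that ring.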